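The source may hold more compounds than are shown below. What is called first, only, known or untested is meant among the compounds shown, and "the series" means these compounds.

Working notes on the series. Going by the values given here, compound 1 `COc1nc(C)c(Nc2nc(Cl)cn([C@H](COC(C)=O)C3CC3)c2=O)cc1C` gives 5.3 nM in an assay on frontal cortex for displacement of a labelled ligand from corticotropin-releasing factor receptor 1 (Rattus norvegicus), with a stated time of 2 h (on this read-out higher numbers stand for weaker inhibition and lower numbers for stronger inhibition), the highest of the three numbers so far. Compound 2 `COc1nc(C)c(Nc2nc(Cl)cn([C@H](COC(=O)c3ccccc3)C3CC3)c2=O)cc1C` gives 1.5 nM in this assay, and compound 3 `COc1nc(C)c(Nc2nc(Cl)cn([C@H](COC(=O)Nc3ccc(Cl)cc3Cl)C3CC3)c2=O)cc1C` gives 1.7 nM in this assay; a 1.1-fold higher number from compound 2 to compound 3 (0.05 log units; within the scatter). Compound 4 `COc1nc(C)c(Nc2nc(Cl)cn([C@H](COC(=O)Nc3cc(Cl)cc(Cl)c3)C3CC3)c2=O)cc1C` is the next member, differing from compound 1 in one place: (3,5-dichlorophenyl)amino in place of methyl on a carbonyl carbon (acetoxy to ((3,5-dichlorophenyl)carbamoyl)oxy). Among the compounds with values here, the steps that bear on this are a 3.1-fold lower number from compound 1 to compound 3 (0.49 log units; beyond the scatter) and a 3.5-fold lower number from compound 1 to compound 2 (0.55 log units; beyond the scatter), both modest lowerings in this assay. For compound 4 a step of comparable size and direction is therefore expected, with a 2.9-fold lower number from compound 1 to compound 4 (0.47 log units; beyond the scatter) as the expected step. The estimate for compound 4 in this assay is 1.8 nM, in a range from 0.8 nM to 4.5 nM.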

Compound 4, half-maximal inhibitory concentration: 1.7 nM
Beside the measured number, compound 4's estimate is 1.1-fold (0.02 log units) above it; the range from low to high includes it.
By their numbers in this assay, from the lowest: compounds 2, 3 and 4 (each within the scatter of the next); then compound 1.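

In this assay, 3,5-dichlorophenyl in place of 2,4-dichlorophenyl on the amide-type nitrogen gives no change at the digits printed from compound 3 to compound 4 (within the scatter), so these two chlorine patterns are not told apart. With a 1.1-fold higher number from compound 2 to compound 4 (0.05 log units; within the scatter) and a 3.1-fold lower number from compound 1 to compound 4 (0.49 log units; beyond the scatter), the (3,5-dichlorophenyl)amino group stays level with phenyl on the carbonyl carbon and repeats the lowering from methyl. No supporting data explain this result. Open, on these data alone, is whether an unsubstituted phenylamino group or a single chlorine would hold the number. Also open, as far as these compounds go, is how a free hydroxyl or a cyclohexylamino group would compare at this position.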